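This account rests on a few compounds, and the source may have more. Where it says the series, first, only, none or still open, it means among the compounds named here.

Measured so far:
- Compound 1 `COc1cccc(-c2cc(=O)c3cc(NC(C)=O)ccc3o2)c1`: > 404000 nM (a limit of the assay, not a number)
- Compound 2 `COc1ccccc1-c1oc2ccc(NC(C)=O)cc2c(=O)c1OC`: 154000 nM

The read-out here is an ADME assay on MT4 cells (Homo sapiens) for cytotoxicity, read by MTT assay, with a stated time of 4 days; a higher number here means that more compound is tolerated, a lower number that less compound is tolerated. Going by the values given here, on this measure, compound 2 gives 154000 nM, the only actual number available. Compound 1 gives > 404000 nM, which is a limit of the assay.

The next compound is compound 3 `COc1cccc(-c2oc3ccc(NC(C)=O)cc3c(=O)c2OC)c1`, which has the same atoms as compound 2, joined differently: 3-methoxyphenyl in place of 2-methoxyphenyl on an aromatic carbon. In words, 3-methoxyphenyl stands in place of 2-methoxyphenyl on an aromatic carbon. Among the compounds with values here, no measured pair shows what such a swap does, so the expectation is no change beyond the usual scatter. The expected 1.2-fold higher number from compound 2 to compound 3 (0.09 log units; within the scatter) is therefore small. For compound 3 the estimated value is 190000 nM, with an expected range of 85000 nM to 350000 nM.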

Compound 3, half-maximal cytotoxic concentration: 369000 nM
For compound 3 the middle estimate is 1.9-fold (0.29 log units) below the measured one; measured number above the stated range.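

In this assay, the same atoms joined differently are not tolerated alike: with 3-methoxyphenyl in place of 2-methoxyphenyl on this aromatic carbon next to the ring oxygen, the result is a 2.4-fold higher number from compound 2 to compound 3 (0.38 log units; beyond the scatter). Compound 3 also differs from compound 1 by methoxy in place of hydrogen on an aromatic carbon, and that step is an at least 1.0-fold lower number from compound 1 to compound 3 (0.03 log units; that floor lies within the scatter), so no effect of this methoxy can be told from the scatter. That comparison rests on a limit of the assay and not on a number: the limit of > 404000 nM in this assay, at which 1 of the 3 values shown sits.

From the compounds shown here alone, it remains open how the cells would tolerate a hydroxy group or an amine in place of the methoxy on the phenyl ring. Going by these compounds, whether the step between these two methoxyphenyl groups would hold on another core also stays unknown.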